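Series notes: the substituent on the chain carbon of compound 3

The source may report more compounds than this note shows. Statements on the series, on what has been measured and on what is new or still open speak of the compounds shown alone.

Compound 3 `Cc1nc2c(OCc3ccccc3)cccn2c1CC1=NCCN1` stands second highest of the three numbers in a functional assay on the whole organism with Rattus norvegicus as the target, with a stated time of 4 h, at a dose of 40 mg/kg by the intraperitoneal route (on this read-out lower numbers stand for less inhibition and higher numbers for more inhibition at the one dose given (going by the name of the read-out)), where compound 3 gives 69%. Nearest is compound 2 `COCc1c(C)nc2c(OCc3ccccc3)cccn12` with 99%; the step is a number 30 percentage points lower from compound 2 to compound 3 (beyond the scatter). Furthest is compound 1 `Cc1nc2c(OCc3ccccc3)cccn2c1C#N` with 25%; here the step is a number 44 percentage points higher from compound 1 to compound 3 (beyond the scatter). Compound 4 `Cc1nc2c(OCc3ccccc3)cccn2c1COC(=O)C(C)(C)C` differs from compound 3 in one place: a group of 7 heavy atoms (5 carbon, 2 oxygen; no ring) in place of a group of 5 heavy atoms (3 carbon, 2 nitrogen; one five-membered non-aromatic ring with 2 hetero atoms), on a saturated chain carbon bound to an aromatic carbon. The measured step that bears on this is a number 30 percentage points lower from compound 2 to compound 3 (beyond the scatter), which ran in the opposite direction at the same position, from the methoxymethyl group of compound 2 to the ring of compound 3. Going by the values given here, compound 4 carries an oxygen-bearing group at that position again, so in this assay a rise a number 16 percentage points higher from compound 3 to compound 4 (beyond the scatter) is expected for compound 4, though no measured step covers the tert-butyl carbonyl itself. Compound 4 is therefore estimated at 85%, between 55% and 100%.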

Compound 4, a percentage reported as inhibition, in the whole organism at one dose (the size of the read-out at that dose, not a potency): 48%
For compound 4 the middle estimate is 37 percentage points above the measured one, outside the stated range (below it).
By their numbers in this assay, from the lowest: compound 1; then compound 4; then compound 3; then compound 2.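

In this assay an oxygen on the chain carbon does not by itself keep the number high: with (tert-butyl)carbonyl in place of methyl on that oxygen, the step is a number 51 percentage points lower from compound 2 to compound 4 (beyond the scatter) and it is large. The order at this position is therefore not simply oxygen groups over the ring, since the step is a number 21 percentage points lower from compound 3 to compound 4 (beyond the scatter), while the step of a number 23 percentage points higher from compound 1 to compound 4 (beyond the scatter) leaves the new group still ahead of cyano. Nothing at hand explains these differences. Open, on these data alone, is where a hydroxymethyl group or an aminomethyl group on the aromatic carbon would fall, and whether acetyl in place of (tert-butyl)carbonyl would stand nearer compound 2 or compound 4.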